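Hydrazone aryl variation on the shared core

The source may hold more compounds than are shown below. What is called first, only, known or untested is meant among the compounds shown, and "the series" means these compounds.

Measured so far in a functional assay on PC-3 cells (Homo sapiens) for antiproliferative activity, read by MTT assay; a higher number here means a weaker inhibitor, a lower number a stronger inhibitor:
- compound 1, `Cn1c(=O)c(=O)n(C2CCCC2)c2nc(N/N=C/c3ccc(Cl)cc3)ncc21`: 8420 nM
- compound 2, `Cn1c(=O)c(=O)n(C2CCCC2)c2nc(N/N=C/c3ccc(F)c(Cl)c3)ncc21`: 8550 nM
- compound 3, `Cn1c(=O)c(=O)n(C2CCCC2)c2nc(N/N=C/c3cccc(O)c3)ncc21`: 36300 nM

Compound 1 gives the lowest number of the three, but compound 2 sits so close that no order between them can be read: a 1.0-fold higher number from compound 1 to compound 2 (0.01 log units; within the scatter). Compound 3 stands apart from both, with a 4.3-fold higher number from compound 1 to compound 3 (0.63 log units; beyond the scatter) and a 4.2-fold higher number from compound 2 to compound 3 (0.63 log units; beyond the scatter). So far, then, swapping one halogenated phenyl for another leaves the readout unchanged, while the 3-hydroxyphenyl variant costs a modest amount.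

The unmeasured compound 4, `Cn1c(=O)c(=O)n(C2CCCC2)c2nc(N/N=C/c3cccc([N+](=O)[O-])c3)ncc21`, differs from compound 1 in one place: 3-nitrophenyl in place of 4-chlorophenyl on a carbon with a double bond to nitrogen. For the measured compounds named here, two steps bear on this. The step from compound 1 to compound 2 shows that a change within the halogenated phenyl set does nothing beyond the scatter. The step from compound 1 to compound 3 shows that moving to a 3-substituted phenyl carrying hydrogen-bond acceptor character raises the number modestly. The 3-nitrophenyl group shares the latter feature but lacks the donor, so a smaller rise than seen for compound 3, or none beyond the scatter, is expected: a 1.8-fold higher number from compound 1 to compound 4 (0.25 log units; within the scatter). Compound 4 is therefore estimated at 15000 nM in this assay, with a plausible range from 6000 nM to 40000 nM.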

Compound 4, half-maximal inhibitory concentration: 20300 nM
For compound 4 the middle estimate is 1.4-fold (0.13 log units) below the measured one; low and high end bracket the measured number.
By their numbers in this assay, from the lowest: compounds 1 and 2 (each within the scatter of the next); then compounds 4 and 3 (each within the scatter of the next).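

In this assay, the 3-nitrophenyl group on this carbon with a double bond to nitrogen separates from both halogenated compounds (a 2.4-fold higher number from compound 1 to compound 4 (0.38 log units; beyond the scatter); a 2.4-fold higher number from compound 2 to compound 4 (0.38 log units; beyond the scatter)), so a modest rise at this place is no longer confined to the 3-hydroxyphenyl of compound 3. Nitro in place of hydroxy on an aromatic carbon gives no readable change (a 1.8-fold lower number from compound 3 to compound 4 (0.25 log units; within the scatter)), which places compound 3 and compound 4 together, with the 4-chlorophenyl and 3-chloro-4-fluorophenyl compounds forming the lower pair and neither of the four compounds going against this split. No measurement shown here accounts for the split between the halogenated and non-halogenated groups.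

Still open, going by these compounds, is how a plain phenyl, a 4-nitrophenyl, a 3-aminophenyl or a 3-methoxyphenyl group would read on this carbon, which would show whether the rise follows the loss of halogen or the identity of the incoming group. Also open, on these data alone, is whether a carboxylic acid or a longer chain on the phenyl ring would stay with compound 3 and compound 4 or move beyond them.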